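The source may hold more compounds than are shown below. What is called first, only, known or untested is meant among the compounds shown, and "the series" means these compounds.

Of the compounds shown here, three sharing one core have been tested in an ADME assay on L02 cells (Homo sapiens) for cytotoxicity, read by MTT assay, with a stated time of 24 h; a higher number here means a weaker inhibitor, a lower number a stronger inhibitor. Compound 1 `O=C1/C(=C/c2cccnc2)CN(S(=O)(=O)c2ccccc2)C/C1=C\c1ccccc1F` gives 15300 nM, and compound 3 `O=C1/C(=C/c2cccnc2)CN(S(=O)(=O)c2ccc(Br)cc2)C/C1=C\c1ccccc1F`, which carries a 4-bromophenyl group, gives 14600 nM. These two stand level, as the step shows: a 1.0-fold lower number from compound 1 to compound 3 (0.02 log units; within the scatter). Compound 2 `O=C1/C(=C/c2cccnc2)CN(S(=O)(=O)c2ccc([N+](=O)[O-])cc2)C/C1=C\c1ccccc1F` gives > 20000 nM, and this value is a limit of the assay, not a number.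

The next compound is compound 4 `N#Cc1ccc(S(=O)(=O)N2C/C(=C\c3cccnc3)C(=O)/C(=C/c3ccccc3F)C2)cc1`, in which cyano takes the place of bromo on an aromatic carbon, para to a large group: cyano in place of bromo on an aromatic carbon. The same difference can be read as 4-bromophenyl to 4-cyanophenyl.

Among the compounds with values here, no measured step makes this exact swap, so the closest guides are the other group changes of this kind. Bromo in place of hydrogen gave a 1.0-fold lower number from compound 1 to compound 3 (0.02 log units; within the scatter). Nitro in place of hydrogen gave an at least 1.3-fold higher number from compound 1 to compound 2 (0.11 log units; that floor lies within the scatter), and bromo in place of nitro gave an at least 1.3-fold lower number from compound 2 to compound 3 (0.13 log units; that floor lies within the scatter). None of these steps is shown to go beyond the scatter, so no step beyond the scatter is expected in this assay here. The expected change is a 1.1-fold higher number from compound 3 to compound 4 (0.04 log units; within the scatter). For compound 4 the estimated value is 16000 nM, with an expected range from 10500 nM to 25000 nM.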

Compound 4, half-maximal inhibitory concentration: > 20000 nM
Compound 4 was reported as a limit; the forecaster's own chance of this, stated with the estimate: 25%; at least 1.2-fold (0.09 log units) between middle value and limit.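

In this assay compound 4 gives > 20000 nM, which is a limit of the assay and not a number. Cyano in place of bromo gives an at least 1.3-fold higher number from compound 3 to compound 4 (0.13 log units; that floor lies within the scatter), and cyano in place of hydrogen gives an at least 1.3-fold higher number from compound 1 to compound 4 (0.11 log units; that floor lies within the scatter); each of these is only a floor, so the true step may stay within the scatter or may be larger. Compound 4 now shares its limit with compound 2, a second group at this place to do so, and the step between the two cannot be read: the limit of > 20000 nM in this assay, at which 2 of the 4 values shown sit.

With limits among the values shown, it remains open how far compound 2 and compound 4 truly lie from compound 1 and compound 3, and no change at this place has yet been shown to go beyond the scatter. An amine or a carboxylic acid on the same ring position would show whether any group here can bring the number clearly lower than the level of compound 1 and compound 3.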